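Hydroxy for Phenyl on the Carbonyl Side Chain

The compounds below may be only part of what the source reports. "The series", "measured", "known", "first", "only" and "open" are said of these compounds alone.

Compound 1 `COc1cc(-c2nnc3n2NC(c2ccco2)C(C(=O)c2ccco2)S3)cc(OC)c1OC` gives > 100000 nM in a functional assay on HepG2 cells (Homo sapiens) for cytotoxicity, read by MTT assay, with a stated time of 48 h; a higher number here means a weaker inhibitor, a lower number a stronger inhibitor.
Compound 2 `COc1cc(-c2nnc3n2NC(c2ccco2)C(C(=O)C2CC2)S3)cc(OC)c1OC` gives > 100000 nM in this assay.
Compound 3 `COc1cc(-c2nnc3n2NC(c2ccco2)C(C(=O)c2ccc(-c4ccccc4)cc2)S3)cc(OC)c1OC` gives > 100000 nM in this assay.

For compound 1 this value is a limit of the assay, not a number. The same is true for compound 2. For compound 3 it is also a limit, so compound 3 stands where every other compound stands, at the limit of > 100000 nM in this assay, at which 3 of the 3 values shown sit.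

The change to compound 4 `COc1cc(-c2nnc3n2NC(c2ccco2)C(C(=O)c2ccc(O)cc2)S3)cc(OC)c1OC` is hydroxy in place of phenyl on an aromatic carbon. Among the compounds with values here, three measured steps touch the same carbonyl side chain: a step that the two limits leave unreadable from compound 1 to compound 2, a step that the two limits leave unreadable from compound 1 to compound 3 and a step that the two limits leave unreadable from compound 2 to compound 3. All three are unreadable, since both ends sit at the limit, so none of them gives a size to lean on. Within the data shown here, no measured compound here carries a hydroxy group in place of phenyl. The data give no size for such a change.

Compound 4 is therefore expected at 150000 nM, with a range from 50000 nM to 500000 nM. The step that this estimate implies, a step that the limit leaves unreadable from compound 3 to compound 4, is expected to be none beyond the scatter, and most likely only a limit will be recorded again.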

Compound 4, half-maximal inhibitory concentration: > 100000 nM
Compound 4: a limit, no number; the forecaster's own chance of this, stated with the estimate: 80%; the middle value is on the limit's open side.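

Compound 4 also gives only a limit of the assay, not a number, so no step from compound 1, compound 2 or compound 3 to compound 4 can be read: the limit of > 100000 nM in this assay, at which 4 of the 4 values shown sit.

The compounds shown leave open whether any group on the carbonyl side chain would give a readable number in this assay.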